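Notes on the phenyl substituent in a furanyl-vinyl series

The source may hold more compounds than are shown below. What is called first, only, known or untested is meant among the compounds shown, and "the series" means these compounds.

Compound 2 `C(=C/c1nn2c(-c3ccccc3)nnc2s1)\c1ccco1` carries an unsubstituted phenyl on the shared core. Among the measured compounds shown here, in an assay for binding affinity to histone-lysine N-methyltransferase, H3 lysine-79 specific (Homo sapiens), read by surface plasmon resonance (a lower number here means tighter binding, a higher number weaker binding), compound 2 gives 4780 nM, the highest of the two numbers measured so far. Its nearest neighbour is compound 1 `Cc1cccc(-c2nnc3sc(/C=C/c4ccco4)nn23)c1`, which has a methyl on an aromatic carbon of that ring; in this assay compound 1 gives 1210 nM. For the measured compounds named here, the only recorded step, a 4.0-fold higher number from compound 1 to compound 2 (0.60 log units; beyond the scatter), shows that loss of the methyl moves the number upward beyond the scatter.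

Compound 3 `CN(C)c1ccc(-c2nnc3sc(/C=C/c4ccco4)nn23)cc1` is not yet measured. It differs from compound 2 by dimethylamino in place of hydrogen on an aromatic carbon. Going by the values given here, no measured pair carries a dimethylamino, and no measured pair varies this place on the ring, so the single methyl step is the only guide to the size of a substituent effect here. For compound 3 the expected value in this assay is 2500 nM, with a range from 600 nM to 10000 nM. Among the compounds with values here, this estimate corresponds to a step of a 1.9-fold lower number from compound 2 to compound 3 (0.28 log units; within the scatter), expected downward and modest, wide in range because the sole comparison available is a 4.0-fold higher number from compound 1 to compound 2 (0.60 log units; beyond the scatter).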

Compound 3, dissociation constant: 9300 nM
For compound 3 the middle estimate is 3.7-fold (0.57 log units) below the measured one, and the stated range covers the measured number.
By their numbers in this assay, from the lowest: compound 1; then compounds 2 and 3 (each within the scatter of the next).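

In this assay, dimethylamino in place of hydrogen on an aromatic carbon, para to a large group, gives a 1.9-fold higher number from compound 2 to compound 3 (0.29 log units; within the scatter), so this change does not separate compound 3 from compound 2. Among the compounds shown here, this is the first reading at this place on the ring, and it shows that a group of 3 heavy atoms, with no ring and no net charge, can stand there without a change beyond the scatter, whereas the earlier comparison covered only the methyl of compound 1 and the hydrogen of compound 2. Nothing available here gives a reason for this result or for the difference between the two steps.

The compounds shown leave open whether a methyl at the place para to a large group would give the same number as the methyl of compound 1 at its own place, and so whether the earlier step depends on the group, the place or both. They also leave open how other groups at this place, such as a primary amine, a methoxy group or a carboxylic acid, would read in this assay.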